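From 3-acetamidophenyl to 3-cyanophenyl

A few compounds are considered here, and "the series" means these few. Any claim that something is new, unique, unknown or untested is made for them only; others in the source may bear on it.

Measured in a functional assay on HL-60 cells (Homo sapiens) for inhibition, read by MTT assay, with a stated time of 72 h (a higher number here means a weaker inhibitor, a lower number a stronger inhibitor), so far
compound 1 `CC(=O)c1ccc(N2CCN(C(=O)c3oc(C)nc3-c3ccccc3)CC2)cc1` gives "not active" (no number reported)
compound 2 `Cc1nc(-c2ccccc2)c(C(=O)N2CCN(c3cccc(C(F)(F)F)c3)CC2)o1` gives 153 nM
compound 3 `CC(=O)Nc1cccc(N2CCN(C(=O)c3oc(C)nc3-c3ccccc3)CC2)c1` gives 329 nM

Compound 3 at 329 nM holds the higher of the two numbers, while compound 1 offers no number for comparison. Compound 4 `Cc1nc(-c2ccccc2)c(C(=O)N2CCN(c3cccc(C#N)c3)CC2)o1` carries cyano in place of acetamido on an aromatic carbon and has not been measured. Going by the values given here, the one measured step at this place is a 2.2-fold higher number from compound 2 to compound 3 (0.33 log units; beyond the scatter) and it is modest, with acetamido entering in place of trifluoromethyl. Losing acetamido is therefore expected to give a similarly modest move to a lower number in this assay, although no cyano compound has been measured. The expected step is a 1.5-fold lower number from compound 3 to compound 4 (0.17 log units; within the scatter) and it may not clear the scatter. The estimate for compound 4 is 220 nM (range 80 nM to 600 nM).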

Compound 4, half-maximal inhibitory concentration: 39.6 nM
The estimate for compound 4 lay 5.6-fold (0.74 log units) above the measured number; measured number below the stated range.
By their numbers in this assay, from the lowest: compound 4; then compound 2; then compound 3.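

In this assay the place meta to a large group responds more strongly than the earlier pair showed: cyano in place of acetamido gives an 8.3-fold lower number from compound 3 to compound 4 (0.92 log units; beyond the scatter) and cyano in place of trifluoromethyl gives a 3.9-fold lower number from compound 2 to compound 4 (0.59 log units; beyond the scatter) in this set. Among the three groups compared here, cyano therefore gives the lowest number, with both steps beyond the scatter. No supporting data are available to account for either step. From the compounds shown here alone, whether a primary amine, a carboxylic acid or a longer chain at this place would go lower or higher remains open. Also open, going by these compounds, is whether cyano would hold its advantage elsewhere on the aromatic ring.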